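The compounds below may be only part of what the source reports. "The series", "measured", "known", "first", "only" and "open" are said of these compounds alone.

Compound 1 `O=C(NC(=S)NNc1ncnc2ccccc12)c1ccccc1F`: 5010 nM in a functional assay on MGC-803 cells (Homo sapiens) for cytotoxicity, read by MTT assay, with a stated time of 72 h; on this read-out lower numbers stand for stronger inhibition and higher numbers for weaker inhibition
Compound 2 `COc1ccccc1C(=O)NC(=S)NNc1ncnc2ccccc12`: 14300 nM
Compound 3 `O=C(NC(=S)NNc1ncnc2ccccc12)c1ccc(Cl)cc1`: 1860 nM

Compound 3 gives the lowest number of the three in this assay. Its nearest neighbour is compound 1, with a 2.7-fold lower number from compound 1 to compound 3 (0.43 log units; beyond the scatter), and its furthest is compound 2, with a 7.7-fold lower number from compound 2 to compound 3 (0.89 log units; beyond the scatter). Compound 4 `O=C(NC(=S)NNc1ncnc2ccccc12)c1cccc(Cl)c1` has not yet been measured; it differs from compound 3 by 3-chlorophenyl in place of 4-chlorophenyl on a carbonyl carbon.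

Among the measured compounds shown here, none of the measured steps changes a chlorine alone. For the measured compounds named here, the steps that bear on the new compound all exchange the whole aryl group on the carbonyl carbon: a 2.7-fold lower number from compound 1 to compound 3 (0.43 log units; beyond the scatter) and a 7.7-fold lower number from compound 2 to compound 3 (0.89 log units; beyond the scatter), while a 2.9-fold higher number from compound 1 to compound 2 (0.46 log units; beyond the scatter) shows that swapping one group for another on the aromatic carbon also moves the number, though only modestly. The three steps together show that this part of the molecule tolerates change without large shifts, and that the 4-chlorophenyl of compound 3 gives the lowest number seen so far. A move away from it is therefore expected to give a somewhat higher number in this assay, with a 1.6-fold higher number from compound 3 to compound 4 (0.19 log units; within the scatter) expected as the likely size, and a step within the scatter being quite possible.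

Compound 4 is expected to give about 2900 nM in this assay, within a range of 1300 nM to 6500 nM.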

Compound 4, half-maximal inhibitory concentration: 4540 nM
Compound 4: the middle estimate sits 1.6-fold (0.19 log units) below what was measured; low and high end bracket the measured number.
By their numbers in this assay, from the lowest: compound 3; then compounds 4 and 1 (each within the scatter of the next); then compound 2.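

Moving the chlorine alone, with the same atoms present, gives a 2.4-fold higher number from compound 3 to compound 4 (0.39 log units; beyond the scatter) in this assay, the first step here that keeps the substituent unchanged, and it shows that where the chlorine sits on the aryl group matters beyond the scatter. The 3-chlorophenyl group does not separate from the 2-fluorophenyl group, with a 1.1-fold lower number from compound 1 to compound 4 (0.04 log units; within the scatter), while it stands apart from the 2-methoxyphenyl group, with a 3.1-fold lower number from compound 2 to compound 4 (0.50 log units; beyond the scatter), so a chlorine on the aryl group does not by itself bring the number down to that of compound 3, which remains the lowest of the four. No measurement is available that could explain this shift, and the reason for it stays unknown.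

The compounds shown leave open whether the 4-chlorophenyl advantage is specific to chlorine or would carry over to a bromine, a trifluoromethyl group or an amine on the aryl group. They also leave open whether the order seen among these four compounds would hold on any other cell line.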